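The source may report more compounds than this note shows. Statements on the series, on what has been measured and on what is new or still open speak of the compounds shown alone.

The series shares one core, shown by compound 1, `O=[N+]([O-])c1ccc(CN2CCC(n3cc(CC(OCc4cc(-c5ccc(F)cc5)no4)c4ccc(Br)cc4)nn3)CC2)cc1`. In a functional assay on PC-3 cells (Homo sapiens) for cytotoxicity, with a stated time of 48 h (a lower number here means a stronger inhibitor, a higher number a weaker inhibitor), compound 1 gives only a limit, > 25000 nM. Compound 2, `COc1ccc(-c2cc(COC(Cc3cn(C4CCN(Cc5ccc([N+](=O)[O-])cc5)CC4)nn3)c3ccc(Br)cc3)on2)cc1`, carries a 4-methoxyphenyl where compound 1 has a 4-fluorophenyl; in this assay compound 2 gives 3000 nM, and the step is an at least 8.3-fold lower number from compound 1 to compound 2 (0.92 log units; beyond the scatter). Compound 3, `O=[N+]([O-])c1ccc(CN2CCC(n3cc(CC(OCc4cc(-c5cccc(Br)c5)no4)c4ccc(Br)cc4)nn3)CC2)cc1`, carries a 3-bromophenyl on the same aromatic carbon. In this assay compound 3 gives only a limit, > 25000 nM. Compound 3 thus sits at the weak end of what is shown, at the limit of > 25000 nM in this assay, at which 2 of the 3 values shown sit; the step of an at least 8.3-fold higher number from compound 2 to compound 3 (0.92 log units; beyond the scatter), while the step that the two limits leave unreadable from compound 1 to compound 3.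

Compound 4, `COc1ccccc1-c1cc(COC(Cc2cn(C3CCN(Cc4ccc([N+](=O)[O-])cc4)CC3)nn2)c2ccc(Br)cc2)on1`, is not yet measured. The change from compound 3 is 2-methoxyphenyl in place of 3-bromophenyl on an aromatic carbon. Among the measured compounds shown here, the one measured step that bears on it is the move from a methoxyphenyl to the 3-bromophenyl, the reverse of an at least 8.3-fold higher number from compound 2 to compound 3 (0.92 log units; beyond the scatter); that step, however, concerns the 4-methoxyphenyl of compound 2, and no measured pair shows what a 2-methoxyphenyl does in place of a 4-methoxyphenyl. A downward step in this assay is therefore expected, an at least 3.1-fold lower number from compound 3 to compound 4 (0.49 log units; beyond the scatter), with wide uncertainty. Compound 4 is estimated at 8000 nM, within 2000 nM to 40000 nM.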

Compound 4, half-maximal inhibitory concentration: > 25000 nM
Compound 4: a limit, no number; the forecaster's own chance of this, stated with the estimate: 40%; middle value at least 3.1-fold (0.49 log units) from the limit.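

In this assay, the step from 4-methoxyphenyl to 2-methoxyphenyl on this aromatic carbon next to the ring nitrogen is an at least 8.3-fold higher number from compound 2 to compound 4 (0.92 log units; beyond the scatter), so among the compounds shown, a methoxyphenyl at this place does not by itself give the value of compound 2. Compound 4 gives only a limit, > 25000 nM, and the steps that join it to the other two limits cannot be read. Compound 2 therefore remains the only compound in the series with a measured number, as the other three share one end of what is shown: the limit of > 25000 nM in this assay, at which 3 of the 4 values shown sit.

Going by these compounds, whether a 3-methoxyphenyl, a 4-hydroxyphenyl or a 4-aminophenyl at this place would give a number rather than a limit stays open. Also open, on these data alone, is whether the value of compound 2 holds when the shared core is changed elsewhere, for example with an amine in place of the nitro group or a chlorine in place of the bromine.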